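The source may hold more compounds than are shown below. What is called first, only, known or untested is meant among the compounds shown, and "the series" means these compounds.

Measured in an ADME assay on Colon (Mus musculus, strain C57BL/6) for metabolic stability, read by HPLC, with a stated time of 12 h; a higher number here means that the compound lasts longer, a lower number that the compound disappears faster:
- Compound 1 `O=C(O)[C@@H](CO)NC(=O)[C@H]1C[C@H](O)CN1`: > 12 h
- Compound 2 `O=C(O)[C@H](CO)NC(=O)[C@H]1C[C@@H](O)CN1`: > 12 h

Compound 2 gives > 12 h in this assay, and this is a limit of the assay, not a number. Compound 1 gives > 12 h, which is also a limit. Both compounds therefore sit at the limit of > 12 h in this assay, at which 2 of the 2 values shown sit.

Compound 3 `O=C(N[C@H](CO)C(=O)O)[C@@H]1C[C@@H](O)CN1` has not been measured. Its change from compound 2 is this: the two compounds have the same atoms and bonds and differ only in configuration as drawn: 2 of 3 stereo elements differ; a stereocentre at a saturated chain carbon is drawn S in compound 2 and R in compound 3; a stereocentre at a saturated ring carbon is drawn R in compound 2 and S in compound 3.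

Going by the values given here, only one measured step bears on this change: a step that the two limits leave unreadable from compound 1 to compound 2. That step is comparable in kind, given (the fact that compounds 1 and 2 differ only in the configuration as drawn), but it offers no size to carry over. No shift in either direction is therefore expected beyond the scatter, and the estimated step is a step that the limit leaves unreadable from compound 2 to compound 3. For compound 3 the expected value is 14 h. The estimated range for compound 3 runs from 10 h to 24 h, and the assay will most likely report only a limit again.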

Compound 3, half-life: > 12 h
Compound 3: only a limit was reported; the forecaster's own chance of this, stated with the estimate: 90%; the middle value is on the limit's open side.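

Going by these compounds alone, no step among compound 1, compound 2 and compound 3 can be read, because all three results are limits of the assay, not numbers: the limit of > 12 h in this assay, at which 3 of the 3 values shown sit. The compounds shown leave open how long each one actually lasts in this assay, and whether configuration as drawn matters for half-life at all.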